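Dimethylamino for Methoxy on a P2X7 Antagonist Benzamide

The source may report more compounds than this note shows. Statements on the series, on what has been measured and on what is new or still open speak of the compounds shown alone.

Of the compounds shown here, two have so far been measured in an assay on THP-1 cells for antagonist activity at P2X purinoceptor 7 (Homo sapiens), read by ELISA, with a stated time of 30 min; on this read-out lower numbers stand for stronger inhibition and higher numbers for weaker inhibition. Compound 1 `CNC(=O)c1cccc(S(=O)(=O)Oc2ccc(-c3cncn3C3CCN(C(=O)c4ccc(Cl)c(C(F)(F)F)c4)CC3)cc2)c1` gives 1.76 nM in this assay. Compound 2 `COc1ccc(C(=O)N2CCC(n3cncc3-c3ccc(OS(=O)(=O)c4cccc5cnccc45)cc3)CC2)cc1` gives 64 nM, the higher of the two numbers, standing a long way from compound 1 and well beyond the scatter of repeated measurements. Compound 3 `CN(C)c1ccc(C(=O)N2CCC(n3cncc3-c3ccc(OS(=O)(=O)c4cccc5cnccc45)cc3)CC2)cc1` is not yet measured; it differs from compound 2 by dimethylamino in place of methoxy on an aromatic carbon. For the measured compounds named here, no measured pair here shows the effect of such a change, so there is no step to lean on. With one group traded for another at the same position, the number is expected to move little, in either direction, and most likely not beyond the scatter. Compound 3 is therefore expected to give about 50 nM in this assay, somewhere between 15 nM and 200 nM. The expected step is a 1.3-fold lower number from compound 2 to compound 3 (0.11 log units; within the scatter).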

Compound 3, half-maximal inhibitory concentration: 2.19 nM
Compound 3: middle estimate off by 23-fold (1.36 log units), on the high side; the measured number lies below the stated range.
By their numbers in this assay, from the lowest: compounds 1 and 3 (each within the scatter of the next); then compound 2.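

In this assay, dimethylamino in place of methoxy gives a 29-fold lower number from compound 2 to compound 3 (1.47 log units; beyond the scatter), showing that this position, on an aromatic carbon para to a large group, is highly sensitive to which group it carries. The sensitivity appears even though the two groups have the same counts of hydrogen-bond donors and acceptors and neither carries a net charge, so those counts do not account for the step. Nothing measured here shows why the change has so large an effect.

For the compounds shown here, with only two groups compared at this position, it remains open whether a plain amino group, a diethylamino group or a pyrrolidine ring would behave like dimethylamino. On these data alone, it also remains open whether the same exchange would produce a similar step on a different core.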